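Propylamide in Place of Morpholine Amide on a Kinase Inhibitor

The source may report more compounds than this note shows. Statements on the series, on what has been measured and on what is new or still open speak of the compounds shown alone.

Compound 1 `CNC(=O)c1cccc(C#Cc2ccccc2Nc2ncnc3ccc(Cl)nc23)c1` gives 4900 nM in an assay on isolated protein for inhibition of MAP kinase-interacting serine/threonine-protein kinase 2 (Homo sapiens), read by HTRF, in the presence of a further agent that is not named here; a higher number here means a weaker inhibitor, a lower number a stronger inhibitor. Compound 2 `O=C(c1cccc(C#Cc2ccccc2Nc2ncnc3ccc(Cl)nc23)c1)N1CCOCC1` reaches only the assay limit, > 10000 nM, so no exact number is known for it; this is the limit of > 10000 nM in this assay, at which 1 of the 2 values shown sits. The measured step of an at least 2.0-fold higher number from compound 1 to compound 2 (0.30 log units; that floor lies within the scatter) shows that the ring amide was the weaker of the pair. Compound 3 `CCCNC(=O)c1cccc(C#Cc2ccccc2Nc2ncnc3ccc(Cl)nc23)c1` reverses that move: propylamino in place of morpholin-4-yl on a carbonyl carbon, restoring an open-chain amide with its amide hydrogen, much as in compound 1. Because the step of an at least 2.0-fold higher number from compound 1 to compound 2 (0.30 log units; that floor lies within the scatter) went upward, the return is expected to go downward, by an at least 2.0-fold lower number from compound 2 to compound 3 (0.30 log units; that floor lies within the scatter). Compound 3 is therefore expected to give 5000 nM, within 1500 nM to 15000 nM.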

Compound 3, half-maximal inhibitory concentration: 3900 nM
For compound 3 the middle estimate is 1.3-fold (0.11 log units) above the measured one; measured number inside the range.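

Replacing morpholin-4-yl with propylamino on the carbonyl carbon gives an at least 2.5-fold lower number from compound 2 to compound 3 (0.40 log units; beyond the scatter), so the open-chain amide clearly outperforms the ring amide. Compound 2 stands at a limit, so that step is only a floor: the limit of > 10000 nM in this assay, at which 1 of the 3 values shown sits. With a 1.3-fold lower number from compound 1 to compound 3 (0.10 log units; within the scatter), methylamino and propylamino cannot be told apart at this position.

From the compounds shown here alone, whether the ring or the loss of the amide hydrogen sets compound 2 apart stays open, since the two change together. Also open, going by these compounds, is whether a longer chain, or a chain ending in an amine or a carboxylic acid, would give a lower number.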